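This account rests on a few compounds, and the source may have more. Where it says the series, first, only, none or still open, it means among the compounds named here.

Within the data shown here, the three compounds measured so far share one core and differ only in the aryl group carried on a carbon of the five-membered ring. In an assay on CHO cells for displacement of a labelled ligand from adenosine receptor A1 (Homo sapiens), read by scintillation counting, with a stated time of 3 h (on this read-out higher numbers stand for weaker inhibition and lower numbers for stronger inhibition), compound 1 `Cn1c(-c2ccc(F)cc2)nc2c(NC3CCCC3)ncnc21` gives 6.2 nM. Compound 2 `Cn1c(-c2cccc(Cl)c2)nc2c(NC3CCCC3)ncnc21` gives 6.5 nM in this assay, and the step of a 1.0-fold higher number from compound 1 to compound 2 (0.02 log units; within the scatter) is within the scatter. Compound 3 `Cn1c(-c2ccccc2Cl)nc2c(NC3CCCC3)ncnc21` gives 37 nM, the highest of the three numbers, and it stands apart from the other two by a 6.0-fold higher number from compound 1 to compound 3 (0.78 log units; beyond the scatter) and by a 5.7-fold higher number from compound 2 to compound 3 (0.76 log units; beyond the scatter).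

Compound 4 `Cn1c(-c2cccnc2)nc2c(NC3CCCC3)ncnc21` carries a different ring here: pyridin-3-yl in place of 2-chlorophenyl on an aromatic carbon. Among the measured compounds shown here, no measured compound carries a pyridine ring, so no step speaks to that part of the change directly. For the measured compounds named here, the steps that bear on it are the two leading to compound 3, which show that the 2-chlorophenyl group goes with a markedly higher number than the 4-fluorophenyl or 3-chlorophenyl groups. Because a 6.0-fold higher number from compound 1 to compound 3 (0.78 log units; beyond the scatter) and a 5.7-fold higher number from compound 2 to compound 3 (0.76 log units; beyond the scatter) both point this way, a return toward the lower numbers of compound 1 and compound 2 is expected when 2-chlorophenyl leaves. The expected step is a 3.7-fold lower number from compound 3 to compound 4 (0.57 log units; beyond the scatter). Compound 4 is estimated at 10 nM, with a range from 3 nM to 40 nM.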

Compound 4, inhibition constant: 242 nM
For compound 4 the middle estimate is 24-fold (1.38 log units) below the measured one; measured number above the stated range.
By their numbers in this assay, from the lowest: compounds 1 and 2 (each within the scatter of the next); then compound 3; then compound 4.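

In this assay, among these compounds, the aryl group at this place matters more than the earlier compounds showed: pyridin-3-yl gives a higher number than 2-chlorophenyl (a 6.5-fold higher number from compound 3 to compound 4 (0.82 log units; beyond the scatter)), and the gap is large against 3-chlorophenyl (a 37-fold higher number from compound 2 to compound 4 (1.57 log units; beyond the scatter)) and 4-fluorophenyl (a 39-fold higher number from compound 1 to compound 4 (1.59 log units; beyond the scatter)). Removing 2-chlorophenyl therefore does not by itself bring the number down, and compound 4, the only one here with a nitrogen in this ring, has the highest number of the four. No measurement shown here accounts for this rise.

These compounds do not separate the effect of the ring nitrogen from that of losing the halogen, and an unsubstituted phenyl ring at this place would help to tell them apart. Pyridin-4-yl would show whether the result holds for pyridine rings attached through a different ring carbon.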